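Extending the carbamoyl-bearing branch in a benzoyl tripeptide trypsin series

The source may report more compounds than this note shows. Statements on the series, on what has been measured and on what is new or still open speak of the compounds shown alone.

Among the compounds with values here, compound 2 `N=C(N)NCCC[C@H](NC(=O)c1ccccc1)C(=O)N[C@@H](CCCCN)C(=O)N[C@@H](CC(N)=O)c1ccccc1` gives 7.5% in an assay on isolated protein for inhibition of Trypsin (Homo sapiens), read by fluorescence, with a stated time of 15 min, tested at 50 uM (on this read-out lower numbers stand for less inhibition and higher numbers for more inhibition at the one concentration tested (going by the name of the read-out)), the only plain number among the two values shown. Compound 1 `CC(NC(=O)[C@H](CCCCN)NC(=O)[C@H](CCCNC(=N)N)NC(=O)c1ccccc1)(C(N)=O)c1ccccc1` gives <= 5%, which is a limit of the assay rather than a number (the limit of <= 5% in this assay, at which 1 of the 2 values shown sits). The step of a number at least 2.5 percentage points higher from compound 1 to compound 2 (that floor lies within the scatter) is the only measured one and bears on the new design. Compound 3 `CCC(NC(=O)[C@H](CCCCN)NC(=O)[C@H](CCCNC(=N)N)NC(=O)c1ccccc1)(C(N)=O)c1ccccc1` differs from compound 2 by 1-carbamoyl-1-phenylpropyl in place of 2-carbamoyl-1-phenylethyl on an amide-type nitrogen. Given that compound 1 sits at a limit, compound 3 is expected to show inhibition within the scatter of compound 2, with the estimated step of a number 1.5 percentage points lower from compound 2 to compound 3 (within the scatter). Compound 3 is thus estimated at 6%, between 0% and 15%.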

Compound 3, a percentage reported as inhibition, at one concentration (the size of the read-out at that concentration, not a potency): 8.7%
Beside the measured number, compound 3's estimate is 2.7 percentage points below it, within the range that was stated.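

In this assay, the change to 1-carbamoyl-1-phenylpropyl in place of 2-carbamoyl-1-phenylethyl on the amide-type nitrogen gives a number 1.2 percentage points higher from compound 2 to compound 3 (within the scatter), so the two branches cannot be told apart at this position. The step for methyl in place of hydrogen on the saturated chain carbon is a number at least 3.7 percentage points higher from compound 1 to compound 3 (that floor lies within the scatter), and it can be read only as a floor: the limit of <= 5% in this assay, at which 1 of the 3 values shown sits.

The compounds shown leave open whether an amine or a carboxylic acid in place of the carbamoyl group, or a chain longer than propyl, would give a step beyond the scatter at this position.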